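The source may hold more compounds than are shown below. What is called first, only, known or untested is meant among the compounds shown, and "the series" means these compounds.

Measured so far in a functional assay on A549 cells (Homo sapiens) for antiproliferative activity, read by MTT assay, with a stated time of 72 h; a lower number here means a stronger inhibitor, a higher number a weaker inhibitor:
Compound 1, `COc1cc2ncnc(Nc3ccc(Cl)cc3)c2cc1OCCCCC(=O)Nc1ccc(S(N)(=O)=O)cc1`: compound 1 gives > 40000 nM, a limit of the assay rather than a number.
Compound 2, `COc1cc2ncnc(Nc3ccc(F)c(Br)c3)c2cc1OCCCCC(=O)Nc1ccc(S(N)(=O)=O)cc1`: compound 2 gives 16000 nM.

Compound 1 therefore stands at the limit of this assay, as the limit of > 40000 nM in this assay, at which 1 of the 2 values shown sits, records, and only a limit is known for it. For the measured compounds named here, the one measured step, an at least 2.5-fold lower number from compound 1 to compound 2 (0.39 log units; beyond the scatter), exchanges the whole aryl group and says little about a single substituent.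

Compound 3, `COc1cc2ncnc(Nc3ccc(C)cc3)c2cc1OCCCCC(=O)Nc1ccc(S(N)(=O)=O)cc1`, differs from compound 1 by methyl in place of chloro on an aromatic carbon. Going by the values given here, no measured step bears on this exchange: the step from compound 1 to compound 2 involves a different aryl group, so its size cannot be carried over. With compound 1 at the limit, the account can only expect compound 3 to remain weak, and any movement beyond the scatter could go in either direction.

Compound 3 is expected at 40000 nM in this assay, within 12000 nM to 130000 nM, which is an expected step of a number no higher from compound 1 to compound 3 (the limit leaves the size open).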

Compound 3, half-maximal inhibitory concentration: > 40000 nM
Compound 3 ended at the assay's limit (the forecaster's own chance of this, stated with the estimate: 60%); the middle value sits exactly at the limit.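

Methyl in place of chloro on an aromatic carbon, para to a large group, gives no readable change in this assay, because compound 1 and compound 3 both stand at the limit rather than at a number: the limit of > 40000 nM in this assay, at which 2 of the 3 values shown sit.

Compound 3 gives > 40000 nM, which is a limit of the assay and not a number. For the compounds shown here, the exchange of 3-bromo-4-fluorophenyl for 4-methylphenyl on the nitrogen brings an at least 2.5-fold higher number from compound 2 to compound 3 (0.39 log units; beyond the scatter), so both the 4-chlorophenyl group of compound 1 and the 4-methylphenyl group of compound 3 now stand apart from compound 2, the only one of the three compounds with a measured number.

Whether the bromine or the fluorine of compound 2 accounts for its value stays open, as does what an unsubstituted phenyl or a 4-methoxyphenyl group on that nitrogen would give. Also open, from the compounds shown here alone, is how a shorter or longer chain, or a carboxylic acid in place of the sulfonamide, would read in this assay.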